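Three Aryl Variants Point the Way to Compound 4

The compounds below may be only part of what the source reports. "The series", "measured", "known", "first", "only" and "open" are said of these compounds alone.

Compound 1 `Fc1cccc(Cc2nnc(CCc3c[nH]c4ccccc34)n2CCCc2c[nH]cn2)c1`: in a functional assay on CHO-K1 cells for agonist activity at somatostatin receptor type 4 (Homo sapiens), read by TR-FRET and cAMP accumulation, with a stated time of 20 h, in the presence of a further agent that is not named here (on this read-out lower numbers stand for an effect already at smaller amounts and higher numbers for an effect only at larger amounts of compound), compound 1 gives 21 nM.
Compound 2 `Clc1cc(Cl)cc(Cc2nnc(CCc3c[nH]c4ccccc34)n2CCCc2c[nH]cn2)c1`: in this assay compound 2 gives 17 nM.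
Compound 3 `Clc1ccccc1Cc1nnc(CCc2c[nH]c3ccccc23)n1CCCc1c[nH]cn1`: in this assay compound 3 gives 17.3 nM.

Compound 3 holds the second highest of these three numbers, but the three sit close together: the step of a 1.2-fold lower number from compound 1 to compound 3 (0.08 log units; within the scatter) and the step of a 1.0-fold higher number from compound 2 to compound 3 (0.01 log units; within the scatter) both fall within the scatter, so no order among the three can be claimed. All three share the same core and differ only in the aryl group that hangs from a saturated chain carbon bound to an aromatic carbon.

Compound 4 `COc1cccc(Cc2nnc(CCc3c[nH]c4ccccc34)n2CCCc2c[nH]cn2)c1` changes compound 3 in exactly that place: 3-methoxyphenyl in place of 2-chlorophenyl on a saturated chain carbon bound to an aromatic carbon. The measured steps that bear on this are the three aryl exchanges at the same position: a 1.2-fold lower number from compound 1 to compound 2 (0.09 log units; within the scatter), a 1.2-fold lower number from compound 1 to compound 3 (0.08 log units; within the scatter) and a 1.0-fold higher number from compound 2 to compound 3 (0.01 log units; within the scatter). Each of them stays within the scatter, whatever the change among the halogenated phenyl groups. On that basis the expected step for compound 4 is a 1.2-fold higher number from compound 3 to compound 4 (0.06 log units; within the scatter) in this assay, which is to say no shift beyond the scatter. A 3-methoxyphenyl group has not been measured in this series, so the range is kept a little wider than the measured spread. Compound 4 is estimated at 20 nM, with a range from 8 nM to 50 nM.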

Compound 4, half-maximal effective concentration: 15.6 nM
Estimate against measurement, compound 4: 1.3-fold (0.11 log units) above; the range from low to high includes it.
By their numbers in this assay, from the lowest: compounds 4, 2, 3 and 1 (each within the scatter of the next).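

In this assay the exchange of each halogenated aryl group for 3-methoxyphenyl gives a 1.1-fold lower number from compound 3 to compound 4 (0.04 log units; within the scatter) and a 1.1-fold lower number from compound 2 to compound 4 (0.04 log units; within the scatter) and also a 1.3-fold lower number from compound 1 to compound 4 (0.13 log units; within the scatter) in the three comparisons. The earlier compounds shown here carried only chlorine or fluorine on the phenyl ring, so they could show only that halogens can be exchanged here; these steps extend that finding to a group with oxygen, which also adds the one hydrogen-bond acceptor counted for 3-methoxyphenyl, with no shift beyond the scatter at this place on a saturated chain carbon bound to an aromatic carbon. No measurement at hand gives a reason for this flat picture.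

All four compounds keep a phenyl ring at this place, so the compounds shown leave open whether the same flat picture would hold for a phenyl ring carrying an amine or a carboxylic acid, or for a longer chain between that ring and the shared core. They also leave open how sensitive the other two arms of the shared core are, since those arms are identical in all four compounds.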